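The compounds below may be only part of what the source reports. "The series", "measured", "known", "first", "only" and "open" are said of these compounds alone.

Compound 1 `C=CCNc1nc(N)c(C(=O)N=C(N)N)nc1Cl` gives 16% in an assay for inhibition of acid-sensing ion channel 3 (Homo sapiens), read by patch clamp, tested at 1 uM; a higher number here means more inhibition at the concentration tested (going by the name of the read-out), a lower number less inhibition.
Compound 2 `CCCNc1nc(N)c(C(=O)N=C(N)N)nc1Cl` gives 24% in this assay.
Compound 3 `CC(C)(C)Nc1nc(N)c(C(=O)N=C(N)N)nc1Cl` gives "not determined" (no result reported) in this assay.

In this assay compound 2 gives 24%. Among the measured compounds shown here, the only other number comes from compound 1 at 16%, and the step of a number 8 percentage points higher from compound 1 to compound 2 (within the scatter) lies within the usual scatter, so the two cannot be told apart; compound 3 stands at "not determined" (no result reported) and contributes no number at all.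

Compound 4 `NC(N)=NC(=O)c1nc(Cl)c(NCc2ccccc2F)nc1N` has not yet been measured in this assay. It differs from compound 2 by 2-fluorophenyl in place of ethyl on a saturated chain carbon bound to a nitrogen on an aromatic ring. For the measured compounds named here, the one measured step, from compound 1 to compound 2, exchanges one short chain for another and says little about a ring entering at this place, so no measured step truly bears on the change.

Compound 4 is therefore estimated only loosely, with a modest rise in inhibition expected, a number 16 percentage points higher from compound 2 to compound 4 (beyond the scatter). For compound 4 the expected value is 40%, in a range from 15% to 70%.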

Compound 4, a percentage reported as inhibition, at one concentration (the size of the read-out at that concentration, not a potency): 26%
Compound 4: middle estimate off by 14 percentage points, on the high side; low and high end bracket the measured number.
By their numbers in this assay, from the lowest: compounds 1, 2 and 4 (each within the scatter of the next).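

In this assay, among the compounds shown here, the earlier compounds carried only short chains at this place, whereas compound 4 puts 2-fluorophenyl on the saturated chain carbon bound to a nitrogen on an aromatic ring, giving a number 2 percentage points higher from compound 2 to compound 4 (within the scatter) and a number 10 percentage points higher from compound 1 to compound 4 (within the scatter). A six-membered aromatic ring can therefore enter here without compound 4 being told apart from compound 1 or compound 2. Nothing available explains this outcome. From the compounds shown here alone, whether plain phenyl would read differently from 2-fluorophenyl stays open, as does the effect of a longer chain or a terminal amine at this place.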